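The source may report more compounds than this note shows. Statements on the series, on what has been measured and on what is new or still open speak of the compounds shown alone.

Within the data shown here, compound 2 `COc1cc(-c2nnc(SCC(=O)c3ccc(C)cc3)n2N)cc(OC)c1OC` is the only member of this small set with a measured number: in a functional assay on PC-3 cells (Homo sapiens) for antiproliferative activity, read by MTT assay, with a stated time of 48 h (on this read-out higher numbers stand for weaker inhibition and lower numbers for stronger inhibition), compound 2 gives 31300 nM. Compound 1 `COc1cc(-c2nnc(SCC(=O)c3ccc(Cl)cc3)n2N)cc(OC)c1OC` carries chloro where compound 2 carries methyl on an aromatic carbon, and in this assay compound 1 reaches only the limit > 100000 nM. Compound 3 `COc1cc(-c2nnc(SCC(=O)Nc3ccccc3C)n2N)cc(OC)c1OC` has (2-methylphenyl)amino in place of the 4-methylphenyl on the carbonyl carbon, and in this assay compound 3 also sits at the limit > 100000 nM. Two of the three values are thus bounded by the limit of > 100000 nM in this assay, at which 2 of the 3 values shown sit, so the steps of an at least 3.1-fold lower number from compound 1 to compound 2 (0.50 log units; beyond the scatter) and an at least 3.1-fold higher number from compound 2 to compound 3 (0.50 log units; beyond the scatter) are read as lower bounds only, and a step that the two limits leave unreadable from compound 1 to compound 3.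

Compound 4 `COc1cccc(NC(=O)CSc2nnc(-c3cc(OC)c(OC)c(OC)c3)n2N)c1` is not yet measured. Against compound 2 the change is (3-methoxyphenyl)amino in place of 4-methylphenyl on a carbonyl carbon. The step that bears on this is the one from an aryl ketone to an anilide, an at least 3.1-fold higher number from compound 2 to compound 3 (0.50 log units; beyond the scatter), which ran toward weaker inhibition and at least modestly so. The same kind of exchange is made here, with a different substituent on the anilide ring, so a rise in the number is expected, most likely up to the limit of this assay. Compound 4 is therefore expected near 100000 nM, within 30000 nM to 300000 nM. The expected step is a 3.2-fold higher number from compound 2 to compound 4 (0.50 log units; beyond the scatter).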

Compound 4, half-maximal inhibitory concentration: > 100000 nM
Compound 4: a limit, no number; the forecaster's own chance of this, stated with the estimate: 60%; the middle value sits exactly at the limit.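

The exchange of 4-methylphenyl for (3-methoxyphenyl)amino on a carbonyl carbon gives an at least 3.1-fold higher number from compound 2 to compound 4 (0.50 log units; beyond the scatter) in this assay, and this can be read only as a lower bound. A second anilide therefore goes the same way as the first, so among the compounds shown the weaker result does not depend on the 2-methylphenyl ring alone and also appears with 3-methoxyphenyl on the amide-type nitrogen. The remaining new steps cannot be read, because both ends of each step sit at the same bound, and the two anilides cannot be ranked against each other or against the 4-chlorophenyl ketone: the limit of > 100000 nM in this assay, at which 3 of the 4 values shown sit.

No anilide shown yet has a measured number in this assay, so the effect of the ring substituent within that group remains unknown. Going by these compounds, it also remains open whether an amine or a carboxylic acid on the anilide ring, or a longer chain in place of the saturated chain carbon, would bring an anilide within the measurable range or lower the number of a ketone such as compound 2, which gives 31300 nM.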